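Amino Substitution on Two Nucleoside Cores in Cell Growth

The source may hold more compounds than are shown below. What is called first, only, known or untested is meant among the compounds shown, and "the series" means these compounds.

Compound 3 `COc1ncnc2c1c(-c1ccco1)cn2[C@@H]1O[C@H](CO)[C@@H](O)[C@H]1O` carries a methoxy group and a furan ring on its core. In a functional assay on HCT-116 cells (Homo sapiens), read by MTT assay, with a stated time of 72 h (a lower number here means a stronger inhibitor, a higher number a weaker inhibitor), compound 3 gives 40 nM. Compound 1 `COc1nc(N)nc2c1c(-c1ccco1)cn2[C@@H]1O[C@H](CO)[C@@H](O)[C@H]1O` differs from it in one place: amino in place of hydrogen on an aromatic carbon. In this assay compound 1 reaches only a limit of the assay, > 20000 nM. The step of an at least 500-fold higher number from compound 3 to compound 1 (2.69 log units; beyond the scatter) is the single measured instance of this change among the compounds shown.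

Compound 2 `O=c1[nH]cnc2c1c(-c1ccccc1)cn2[C@@H]1O[C@H](CO)[C@@H](O)[C@H]1O` stands on a different core from compound 3; the difference between the two cores is not broken down here. In this assay compound 2 also gives only a limit of the assay, > 100000 nM.

Compound 4 `Nc1nc2c(c(-c3ccccc3)cn2[C@@H]2O[C@H](CO)[C@@H](O)[C@H]2O)c(=O)[nH]1`, not yet measured, arises from compound 2 by the same kind of change: amino in place of hydrogen on an aromatic carbon. The surroundings of the place are not identical, since in compound 3 the position is meta to a methoxy group (2 heavy atoms), whereas in compound 2 it is meta to a group of 1 heavy atom.

The expectation for compound 4 rests on two things: because the measured step of an at least 500-fold higher number from compound 3 to compound 1 (2.69 log units; beyond the scatter) was large and compound 2 already sits at the limit of > 100000 nM in this assay, at which 1 of the 3 values shown sits, no recovery of potency is anticipated. In this assay compound 4 is therefore expected to give about 200000 nM, within an estimated span from 60000 nM to 1000000 nM. The step this estimate implies is expected to be a step that the limit leaves unreadable from compound 2 to compound 4, and the assay will most likely report only a limit again.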

Compound 4, half-maximal inhibitory concentration: > 20000 nM
Compound 4: a limit, no number; the forecaster's own chance of this, stated with the estimate: 90%; the middle value is on the limit's open side.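

In this assay compound 4 gives > 20000 nM, which is a limit of the assay and not a number. Compound 2 also stands at a limit, and the step from compound 2 to compound 4 cannot be read. The compounds shown leave open how much amino in place of hydrogen on an aromatic carbon shifts the value on the core of compound 2.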